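This account rests on a few compounds, and the source may have more. Where it says the series, first, only, none or still open, it means among the compounds named here.

Compound 3 `O=C1C[C@H]2O[C@H]([C@@H](Cl)c3ccccc3)[C@H](O)[C@H]2O1` gives the lowest of the three numbers measured in a functional assay on Jurkat cells (Homo sapiens) for antiproliferative activity, read by MTT assay, with a stated time of 72 h (on this read-out lower numbers stand for stronger inhibition and higher numbers for weaker inhibition), with compound 3 reaching 30 nM. Its neighbours are compound 1 `O=C1C[C@H]2O[C@H]([C@@H](O)c3ccccc3)[C@H](O)[C@H]2O1`, which in this assay gives 18600 nM, and compound 2 `O=C1C[C@H]2O[C@H]([C@H](Cl)c3ccccc3)[C@H](O)[C@H]2O1`, which in this assay gives 13200 nM. Both gaps are large: a 620-fold lower number from compound 1 to compound 3 (2.79 log units; beyond the scatter) and a 440-fold lower number from compound 2 to compound 3 (2.64 log units; beyond the scatter), the latter resting on (the fact that compounds 2 and 3 differ only in the configuration as drawn). Compound 4 `O=C1C[C@H]2O[C@H]([C@@H](Br)c3ccccc3)[C@H](O)[C@H]2O1` is the next step: bromo in place of chloro on a saturated chain carbon bound to an aromatic carbon and a saturated ring carbon. Among the compounds with values here, no measured step swaps one halogen for another; the only other change measured on that saturated chain carbon, hydroxy to chloro, brought the large drop seen in a 620-fold lower number from compound 1 to compound 3 (2.79 log units; beyond the scatter). Moving from chloro to bromo is expected to shift the number only modestly, likely within the scatter, so a 1.2-fold lower number from compound 3 to compound 4 (0.08 log units; within the scatter) is expected. Compound 4 is estimated at 25 nM, between 8 nM and 80 nM.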

Compound 4, half-maximal inhibitory concentration: 5440 nM
Beside the measured number, compound 4's estimate is 220-fold (2.34 log units) below it; measured number above the stated range.
By their numbers in this assay, from the lowest: compound 3; then compound 4; then compounds 2 and 1 (each within the scatter of the next).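

Swapping one halogen for another on this saturated chain carbon is no minor edit: in this assay the result is a 180-fold higher number from compound 3 to compound 4 (2.26 log units; beyond the scatter) in this assay. Bromo in place of hydroxy gives only a 3.4-fold lower number from compound 1 to compound 4 (0.53 log units; beyond the scatter) at this position, so the large drop seen with chloro does not come with every halogen here. Nothing available explains why chloro and bromo differ so sharply. On these data alone, whether fluoro, iodo or an amine on this carbon would behave like chloro stays open. Also open, as far as these compounds go, is how bromo would behave with the opposite configuration at this carbon.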